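This account rests on a few compounds, and the source may have more. Where it says the series, first, only, none or still open, it means among the compounds named here.

Measured in an ADME assay for permeability, using PAMPA; on this read-out higher numbers stand for higher permeability and lower numbers for lower permeability:
compound 1 `CCCC[C@H](NC(=O)[C@H](CCCCN)NC(=O)[C@H](CCCNC(=N)N)NC(=O)c1ccc(/C=C2\SC(=S)N(C3CCCC3)C2=O)cc1)C(N)=O` gives 2.31 10^-6 cm/s
compound 2 `CCCC[C@H](NC(=O)[C@H](CCCCN)NC(=O)[C@H](CCCNC(=N)N)NC(=O)c1ccc(/C=C2\SC(=S)N(Cc3ccc(OC)cc3)C2=O)cc1)C(N)=O` gives 0.6 10^-6 cm/s
compound 3 `C=CCN1C(=O)/C(=C/c2ccc(C(=O)N[C@@H](CCCNC(=N)N)C(=O)N[C@@H](CCCCN)C(=O)N[C@@H](CCCC)C(N)=O)cc2)SC1=S` gives 0.42 10^-6 cm/s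

Compound 3 sits at the bottom of these three numbers, with compound 2 nearest, separated by a 1.4-fold lower number from compound 2 to compound 3 (0.15 log units; within the scatter), and compound 1 furthest, separated by a 5.5-fold lower number from compound 1 to compound 3 (0.74 log units; beyond the scatter). Compound 4 `CCCC[C@H](NC(=O)[C@H](CCCCN)NC(=O)[C@H](CCCNC(=N)N)NC(=O)c1ccc(/C=C2\SC(=S)N(c3ccc(OC)cc3)C2=O)cc1)C(N)=O` differs from compound 3 by 4-methoxyphenyl in place of allyl on an amide-type nitrogen in a ring. Among the compounds with values here, two measured steps bear on this change: a 3.9-fold lower number from compound 1 to compound 2 (0.59 log units; beyond the scatter), which also brings the methoxy-bearing aromatic ring onto this part of the core, and a 1.4-fold lower number from compound 2 to compound 3 (0.15 log units; within the scatter), which removes it again and stays within the scatter. Within the data shown here, no measured compound carries an aromatic ring directly on this ring nitrogen, so the comparison is indirect. On that basis the step of a 1.3-fold higher number from compound 3 to compound 4 (0.12 log units; within the scatter) is expected to be small, within the scatter, with at most a slight upward lean. Compound 4 is therefore estimated at 0.55 10^-6 cm/s, with a range from 0.2 10^-6 cm/s to 1.4 10^-6 cm/s.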

Compound 4, apparent permeability: 0.59 10^-6 cm/s
The estimate for compound 4 lay 1.1-fold (0.03 log units) below the measured number; the measured number falls inside the stated range.
By their numbers in this assay, from the lowest: compounds 3, 4 and 2 (each within the scatter of the next); then compound 1.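

In this assay, setting an aromatic ring directly on this amide-type nitrogen gives no separation from the other non-cycloalkyl groups: a 1.4-fold higher number from compound 3 to compound 4 (0.15 log units; within the scatter) and a 1.0-fold lower number from compound 2 to compound 4 (0.01 log units; within the scatter) are both within the scatter, so 4-methoxyphenyl, 4-methoxybenzyl and allyl cannot be told apart. Shortening the link to the 4-methoxyphenyl ring therefore shows no readable change here. Compound 1 stays apart from all three, now also through a 3.9-fold lower number from compound 1 to compound 4 (0.59 log units; beyond the scatter) and its cyclopentyl group.

No measurement at hand accounts for this separation.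
From the compounds shown here alone, whether an amine, a carboxylic acid or a cyclohexyl ring at this nitrogen would read with compound 1 or with the other three remains open.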